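A few compounds are considered here, and "the series" means these few. Any claim that something is new, unique, unknown or untested is made for them only; others in the source may bear on it.

Compound 1 `CCCNc1cc(Oc2c(OC)cc3cc(C#N)ccc3c2OC)nc(Nc2ccc(C#N)cc2)n1` shows in an ADME assay on MT4 cells (Homo sapiens) for cytotoxicity, read by MTT assay, with a stated time of 5 days (a lower number here means that less compound is tolerated, a higher number that more compound is tolerated), only a limit, > 125000 nM.
Compound 2 `COc1cc2cc(C#N)ccc2c(OC)c1Oc1cc(NC(C)C)nc(Nc2ccc(C#N)cc2)n1` shows in this assay only a limit, > 125000 nM.
Compound 3 `COc1cc2cc(C#N)ccc2c(OC)c1Oc1cc(NCCCOC(C)C)nc(Nc2ccc(C#N)cc2)n1` shows in this assay only a limit, > 125000 nM.

Compound 2 therefore stands at the limit of this assay together with the other two measured compounds, as the limit of > 125000 nM in this assay, at which 3 of the 3 values shown sit, records. The step that the two limits leave unreadable from compound 1 to compound 2 cannot be sized, and the same holds for a step that the two limits leave unreadable from compound 2 to compound 3 and for a step that the two limits leave unreadable from compound 1 to compound 3: changing the substituent on a nitrogen on an aromatic ring from propyl to isopropyl, or to 3-isopropoxypropyl, left every reading at the limit.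

Compound 4 `COc1cc2cc(C#N)ccc2c(OC)c1Oc1cc(NC2CC2)nc(Nc2ccc(C#N)cc2)n1` differs from compound 2 by cyclopropyl in place of isopropyl on a nitrogen on an aromatic ring. The three unreadable steps are the only ones that bear on this change, and none of them moved a reading off the limit. The expectation is therefore that compound 4 likewise gives no readable step in this assay, with a step that the limit leaves unreadable from compound 2 to compound 4 expected to be invisible. Compound 4 is estimated at 150000 nM, within 60000 nM to 400000 nM, most probably reported again as a limit.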

Compound 4, half-maximal cytotoxic concentration: > 125000 nM
Compound 4: no number, only a limit; the forecaster's own chance of this, stated with the estimate: 80%; the middle value does not contradict the limit.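

Among these compounds, compound 4 gives only a limit in this assay, so no step between it and compound 1, compound 2 or compound 3 can be read, and all four share one reading: the limit of > 125000 nM in this assay, at which 4 of the 4 values shown sit.

The compounds shown leave open whether these nitrogen substituents differ at all in this assay.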